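Aryl replacement on the double-bonded chain carbon: compound 3 outlook

This account rests on a few compounds, and the source may have more. Where it says the series, first, only, none or still open, it means among the compounds named here.

Measured compounds:
compound 1 `O=C(COc1ccc(C(=O)/C=C/c2ccc(Cl)cc2Cl)cc1)N[C@H]1CCOC1=O` — 26500 nM
compound 2 `O=C(COc1ccc(C(=O)/C=C/c2ccc(F)cc2)cc1)N[C@H]1CCOC1=O` — > 64000 nM

Compound 1 and compound 2 share one core and differ only in the aryl group carried on the double-bonded chain carbon. In a functional assay on MGC-803 cells (Homo sapiens) for antiproliferative activity, read by MTT assay, with a stated time of 72 h (on this read-out lower numbers stand for stronger inhibition and higher numbers for weaker inhibition), compound 1 gives 26500 nM. For compound 2 the reading is a limit of this assay and not a number, namely > 64000 nM, as noted in the limit of > 64000 nM in this assay, at which 1 of the 2 values shown sits. The step of an at least 2.4-fold higher number from compound 1 to compound 2 (0.38 log units; beyond the scatter) therefore places compound 2 at least modestly behind compound 1. Compound 3 `O=C(COc1ccc(C(=O)/C=C/c2cccc([N+](=O)[O-])c2)cc1)N[C@H]1CCOC1=O` is not yet measured; it differs from compound 2 by 3-nitrophenyl in place of 4-fluorophenyl on a double-bonded chain carbon bound to a double-bonded chain carbon. Going by the values given here, the one measured step concerns a different aryl pair, and no measurement speaks to the 3-nitrophenyl group, so the direction of the change is open. Compound 3 is expected to give about 50000 nM, within 15000 nM to 150000 nM, an estimated step of an at least 1.2-fold lower number from compound 2 to compound 3 (0.10 log units; that floor lies within the scatter).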

Compound 3, half-maximal inhibitory concentration: > 64000 nM
Compound 3: only a limit was reported; the forecaster's own chance of this, stated with the estimate: 45%; at least 1.2-fold (0.10 log units) between middle value and limit.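

In this assay compound 3 reads > 64000 nM, which is a limit of the assay and not a number. Putting 3-nitrophenyl in place of 2,4-dichlorophenyl on a double-bonded chain carbon gives an at least 2.4-fold higher number from compound 1 to compound 3 (0.38 log units; beyond the scatter), so a second aryl replacement now ends behind compound 1, and that with a different group from the 4-fluorophenyl of compound 2. The step between compound 2 and compound 3 cannot be read, which leaves 3-nitrophenyl and 4-fluorophenyl unordered, and compound 1 alone carries a number: the limit of > 64000 nM in this assay, at which 2 of the 3 values shown sit.

Going by these compounds, whether 4-chlorophenyl, with a single chlorine, would keep a readable number at this place remains open. Also open, on these data alone, is how a phenyl bearing an amine or a carboxylic acid would read here, and whether any aryl group would reach below the value of compound 1.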